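Swapping the 4-fluorophenyl group of compound 3

A few compounds are considered here, and "the series" means these few. Any claim that something is new, unique, unknown or untested is made for them only; others in the source may bear on it.

Within the data shown here, in a functional assay on HCT-116 cells (Homo sapiens) for antiproliferative activity, read by MTT assay, with a stated time of 48 h (on this read-out lower numbers stand for stronger inhibition and higher numbers for weaker inhibition), compound 1 (`COc1ccc(-c2c(Nc3cc(OC)c(OC)c(OC)c3)c3ccc(O)cc3oc2=O)cc1`) gives 64200 nM, the only number available in this set. Compound 2 (`COc1ccc(Nc2c(C(=O)C(F)(F)F)c(=O)oc3ccc(OC)cc23)cc1`) has the entry "not determined" (no result reported), and compound 3 (`COc1ccc2oc(=O)c(C(=O)C(F)(F)F)c(Nc3ccc(F)cc3)c2c1`) has the entry "not determined" (no result reported), so compound 3 has no position on the scale. Compound 4 is `COc1ccc2oc(=O)c(C(=O)C(F)(F)F)c(Nc3ccc(C)c(O)c3)c2c1`. The change, (3-hydroxy-4-methylphenyl in place of 4-fluorophenyl on a nitrogen on an aromatic ring), puts 3-hydroxy-4-methylphenyl in place of 4-fluorophenyl on a nitrogen on an aromatic ring. With no number for compound 3, no direction can be argued, and no step beyond the usual scatter is expected in this assay. The sole anchor for an expectation is compound 1 at 64200 nM, which differs in more than this one place. Compound 4 is estimated at 30000 nM, with an expected range of 5000 nM to 120000 nM.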

Compound 4, half-maximal inhibitory concentration: 4620 nM
Compound 4: the middle estimate sits 6.5-fold (0.81 log units) above what was measured; the whole stated range lies above it.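

No step can be read between compound 3 and compound 4, as the entry for compound 3 holds no number. What the 3-hydroxy-4-methylphenyl group contributes to compound 4 stays open, and no evidence speaks to a cause.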